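Two Thioether Enones and an Untested Third

The source may report more compounds than this note shows. Statements on the series, on what has been measured and on what is new or still open speak of the compounds shown alone.

A small set of thioether enones was examined in a functional assay on DU-145 cells (Homo sapiens) for inhibition, read by trypan blue exclusion, with a stated time of 96 h (on this read-out higher numbers stand for weaker inhibition of growth and lower numbers for stronger inhibition of growth), and two of them have been measured so far. Compound 1, `O=C(/C(=C\c1ccc(O)cc1)SCc1ccc(F)cc1)c1ccc(Cl)cc1`, gives 25000 nM in this assay. Compound 2, `COc1ccccc1/C=C(/SCc1ccc(Cl)c(Cl)c1)C(=O)c1ccc(Cl)cc1`, gives 10000 nM in this assay, the lowest of the two numbers recorded, with compound 1 as its nearest neighbour at a gap that lies beyond the usual scatter. Compound 3, `O=C(/C(=C\c1ccc(O)cc1)SCc1ccc(Cl)c(Cl)c1)c1ccc(Cl)cc1`, has not yet been measured in this assay. It differs from compound 2 in one place: 4-hydroxyphenyl in place of 2-methoxyphenyl on a double-bonded chain carbon bound to a double-bonded chain carbon. Going by the values given here, no pair of measured compounds differs in exactly that way, so the size of this kind of step is not known from the data. Compound 1 does carry the 4-hydroxyphenyl group, but it also differs from compound 2 elsewhere, so its value cannot be read as the effect of this change alone. Compound 3 is therefore expected to land somewhere between its two neighbours, at an estimated 15000 nM with a range from 5000 nM to 40000 nM, which would amount to an expected step of a 1.5-fold higher number from compound 2 to compound 3 (0.18 log units; within the scatter).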

Compound 3, concentration for 50% growth inhibition: 1000 nM
Compound 3: the middle estimate sits 15-fold (1.18 log units) above what was measured, outside the stated range (below it).
By their numbers in this assay, from the lowest: compound 3; then compound 2; then compound 1.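

In this assay, going by these compounds alone, the step of a 10-fold lower number from compound 2 to compound 3 (1.00 log units; beyond the scatter) is the first direct reading of 4-hydroxyphenyl in place of 2-methoxyphenyl on a double-bonded chain carbon bound to a double-bonded chain carbon, and it shows that growth inhibition responds clearly to this exchange at this position. Compound 3 also gives a reading at a second position, where 3,4-dichlorophenyl in place of 4-fluorophenyl on a saturated chain carbon bound to a sulfur, with 4-hydroxyphenyl held constant, goes with the larger step of a 25-fold lower number from compound 1 to compound 3 (1.40 log units; beyond the scatter) and stronger inhibition of growth. Nothing available accounts for the size of either step.

On these data alone, each change is read only once, on a single partner, so it remains open whether either step would keep its size with the other group changed. As far as these compounds go, it also remains open whether the first step depends on the hydroxyl group itself, which a plain phenyl group, an aminophenyl group or a ring bearing a carboxylic acid at that chain carbon would help to settle.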